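This account rests on a few compounds, and the source may have more. Where it says the series, first, only, none or still open, it means among the compounds named here.

Measured compounds:
compound 1 `O=C1/C(=C/c2cccnc2)CN(S(=O)(=O)c2ccccc2)C/C1=C\c1ccccc1C(F)(F)F`: 5370 nM
compound 2 `O=C1/C(=C/c2cccnc2)CN(S(=O)(=O)c2ccc(Cl)cc2)C/C1=C\c1ccccc1C(F)(F)F`: 3620 nM

Among the measured compounds shown here, in a functional assay on HepG2 cells (Homo sapiens) for cytotoxicity, read by MTT assay, with a stated time of 24 h (on this read-out higher numbers stand for weaker inhibition and lower numbers for stronger inhibition), compound 2 has the lower of the two numbers, but the only step, a 1.5-fold lower number from compound 1 to compound 2 (0.17 log units; within the scatter), leaves the two compounds within the scatter of each other. Compound 3 `CC(=O)Nc1ccc(S(=O)(=O)N2C/C(=C\c3cccnc3)C(=O)/C(=C/c3ccccc3C(F)(F)F)C2)cc1` differs from compound 2 by acetamido in place of chloro on an aromatic carbon. For the measured compounds named here, the one step that bears on this position, a 1.5-fold lower number from compound 1 to compound 2 (0.17 log units; within the scatter), was within the scatter, and no step with a group of this kind has been measured, so no change beyond the scatter is expected in this assay, in either direction. Compound 3 is estimated at 4000 nM (range 1500 nM to 12000 nM), meaning an expected step of a 1.1-fold higher number from compound 2 to compound 3 (0.04 log units; within the scatter).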

Compound 3, half-maximal inhibitory concentration: 4330 nM
Estimate against measurement, compound 3: 1.1-fold (0.03 log units) below; the range from low to high includes it.
By their numbers in this assay, from the lowest: compounds 2, 3 and 1 (each within the scatter of the next).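

In this assay, the position para to a large group tolerates acetamido as well as chloro or hydrogen: the new steps are (a 1.2-fold higher number from compound 2 to compound 3 (0.08 log units; within the scatter)) and (a 1.2-fold lower number from compound 1 to compound 3 (0.09 log units; within the scatter)). Acetamido adds a hydrogen-bond donor and a hydrogen-bond acceptor that chloro lacks, yet neither step leaves the scatter, so these three compounds cannot be ranked. No evidence accompanying this result accounts for it.

On these data alone, whether an amine or a carboxylic acid at this position would move the number beyond the scatter remains open. The same holds for a longer chain in place of the acetyl part of acetamido.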